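Hydrazide-linked caffeic acid amides: methoxy to hydroxy step

The source may report more compounds than this note shows. Statements on the series, on what has been measured and on what is new or still open speak of the compounds shown alone.

The series shares a hydrazide core. Compound 1 `COc1ccc(C(=O)NNC(=O)/C=C/c2ccc(O)c(O)c2)cc1` carries a methoxy group on one aromatic ring; in a functional assay on NCI-H1299 cells (Homo sapiens) for antiproliferative activity, read by MTT assay, with a stated time of 24 h (a higher number here means a weaker inhibitor, a lower number a stronger inhibitor), compound 1 gives 5420 nM. Compound 2 `O=C(/C=C/c1ccc(O)c(O)c1)NNC(=O)c1ccc(O)cc1` differs by hydrogen in place of methyl on an oxygen on an aromatic ring, and in this assay compound 2 gives 4480 nM; the step of a 1.2-fold lower number from compound 1 to compound 2 (0.08 log units; within the scatter) lies within the scatter. Compound 3 `COc1ccc(C(=O)NNC(=O)/C=C/c2cc(OC)c(O)c(OC)c2)cc1` differs from compound 1 in more than one place, and the difference between the two cores is not broken down here; in this assay compound 3 gives 7450 nM, which sits within the scatter of both compound 1 and compound 2.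

Compound 4 `COc1cc(/C=C/C(=O)NNC(=O)c2ccc(O)cc2)cc(OC)c1O` is not yet measured. It differs from compound 3 by hydrogen in place of methyl on an oxygen on an aromatic ring, the same change already seen between compound 1 and compound 2, on a place described in identical words. For compound 4 the step of a 1.2-fold lower number from compound 3 to compound 4 (0.07 log units; within the scatter) in this assay is expected to be small, because a 1.2-fold lower number from compound 1 to compound 2 (0.08 log units; within the scatter) stayed within the scatter. On this single precedent, compound 4 is estimated at 6300 nM in this assay, with a plausible range from 3200 nM to 12500 nM.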

Compound 4, half-maximal inhibitory concentration: 8710 nM
Compound 4: the middle estimate sits 1.4-fold (0.14 log units) below what was measured, within the range that was stated.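

In this assay, methoxy to hydroxy on the core of compound 3 gives a 1.2-fold higher number from compound 3 to compound 4 (0.07 log units; within the scatter). Set beside the step on the core of compound 1, the new step does not separate from it: the same change on two cores in this assay, a 1.2-fold lower number (0.08 log units; within the scatter) from compound 1 to compound 2 and a 1.2-fold higher number (0.07 log units; within the scatter) from compound 3 to compound 4, 1.4-fold (0.15 log units) apart, within the scatter of two such steps. The change therefore stayed within the scatter on both cores shown, but two pairs in one assay give no direction for it and do not show that it would stay this small on a further core.

Open, on these data alone, is how a longer chain on that oxygen, or an amine or a carboxylic acid in place of the 4-hydroxyphenyl group, would read in this assay. Also open is whether any change at this place can move the number beyond the scatter, as the compounds shown carry only hydrogen or methyl there.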